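This account rests on a few compounds, and the source may have more. Where it says the series, first, only, none or still open, it means among the compounds named here.

Compound 2 `Cc1nc2c3ccccc3ccc2c2nc3c(ccc4ccccc43)c(-c3cccc4ccccc34)c12` gives 12100 nM in a functional assay on AGS cells (Homo sapiens) for cytotoxicity, read by MTT assay, with a stated time of 48 h (on this read-out lower numbers stand for stronger inhibition and higher numbers for weaker inhibition), the lowest of the two numbers in hand; compound 1 `Cc1nc2c3ccccc3ccc2c2nc3c(ccc4ccccc43)c(-c3cccc([N+](=O)[O-])c3)c12` gives 25500 nM. Among the measured compounds shown here, the only measured step, a 2.1-fold lower number from compound 1 to compound 2 (0.32 log units; beyond the scatter), came with naphthalen-1-yl entering for a single substituted phenyl. Compound 3 `Cc1nc2c3ccccc3ccc2c2nc3c(ccc4ccccc43)c(-c3ccccc3S)c12` moves back to a single substituted phenyl: 2-sulfanylphenyl in place of naphthalen-1-yl on an aromatic carbon. For the measured compounds named here, no measured step covers a sulfanyl group, so the expectation leans part way toward compound 1 and its 25500 nM. For compound 3 the expected step is a 1.5-fold higher number from compound 2 to compound 3 (0.17 log units; within the scatter), an estimated 18000 nM within 7000 nM to 45000 nM.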

Compound 3, half-maximal inhibitory concentration: 4070 nM
Beside the measured number, compound 3's estimate is 4.4-fold (0.65 log units) above it; measured number below the stated range.
By their numbers in this assay, from the lowest: compound 3; then compound 2; then compound 1.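

At this position, opposite the ring nitrogen, the number does not simply follow the size of the aryl group: the change to 2-sulfanylphenyl brings a 3.0-fold lower number from compound 2 to compound 3 (0.47 log units; beyond the scatter), despite the loss of one aromatic ring. Among the single substituted phenyls, replacing 3-nitrophenyl brings a 6.3-fold lower number from compound 1 to compound 3 (0.80 log units; beyond the scatter), so the identity of the substituent matters in this assay. No evidence in hand explains these shifts.

Going by these compounds, whether the lower number belongs to the sulfanyl group itself or to its place on the phenyl ring remains open. A hydroxyl or an amine in place of the sulfanyl group would help separate the two.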